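Swapping one aromatic group on compound 2

The source may report more compounds than this note shows. Statements on the series, on what has been measured and on what is new or still open speak of the compounds shown alone.

In an ADME assay on HUVEC cells (Homo sapiens) for inhibition, read by MTT assay, with a stated time of 48 h (on this read-out lower numbers stand for stronger inhibition and higher numbers for weaker inhibition), compound 1 `Fc1ccc(/C=N/Nc2nc(-c3ccc(C(F)(F)F)cc3)cs2)cc1F` gives 79500 nM and compound 2 `Fc1ccc(/C=N/Nc2nc(-c3ccc(F)c(F)c3)cs2)cc1F` gives 59700 nM. These two numbers lie within the usual scatter of each other, so they cannot be told apart. Compound 3 `COc1cc(/C=N/Nc2nc(-c3ccc(F)c(F)c3)cs2)cc(Br)c1OC` returns only a limit of the assay, > 100000 nM. Compound 4 `Fc1ccc(/C=N/Nc2nc(-c3cccc(Br)c3)cs2)cc1F` has not yet been measured. It carries 3-bromophenyl in place of 3,4-difluorophenyl on an aromatic carbon. Among the compounds with values here, no measured pair shows this swap, so in this assay no change beyond the scatter is expected. The estimated step is a 1.2-fold higher number from compound 2 to compound 4 (0.07 log units; within the scatter). Compound 4 is expected to give about 70000 nM, within an estimated range of 30000 nM to 100000 nM.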

Compound 4, half-maximal inhibitory concentration: > 100000 nM
Compound 4 gave a limit, no number (the forecaster's own chance of this, stated with the estimate: 20%); middle value at least 1.4-fold (0.15 log units) away from the limit.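

In this assay, putting 3-bromophenyl in place of 3,4-difluorophenyl at this position gives an at least 1.6-fold higher number from compound 2 to compound 4 (0.22 log units; that floor lies within the scatter). This is the first step read at this position, but it is only a floor, and that floor lies within the scatter, so the change is not shown to weaken inhibition. Its true size cannot be read, because compound 4 gives a limit and not a number: the limit of > 100000 nM in this assay, at which 2 of the 4 values shown sit.

From the compounds shown here alone, it remains open whether any group here would give a number clearly lower than that of compound 2. An amine or a carboxylic acid at this position could begin to answer that.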